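The compounds below may be only part of what the source reports. "The series", "measured", "known", "first", "only" and "open" are said of these compounds alone.

Working notes on the series. Of the compounds shown here, two carry numbers so far. Compound 1 `CCO/C(O)=C1\C(COCCn2ccnn2)=NC(C)=C(C(=O)OC)C1c1cccc(Cl)c1Cl` gives 5.01 nM in a functional assay (aorta) with Rattus norvegicus as the target; on this read-out higher numbers stand for weaker inhibition and lower numbers for stronger inhibition. Compound 2 `CCO/C(O)=C1\C(COCCn2nncc2C(N)=O)=NC(C)=C(C(=O)OC)C1c1ccccc1Cl` gives 100 nM in this assay, the highest of the two numbers; its nearest neighbour is compound 1, whose number is lower by a margin beyond the scatter. The two compounds differ in more than one place, so no single step can be read from this pair.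

The next compound, compound 3 `CCO/C(O)=C1\C(COCCn2nncc2C(N)=O)=NC(C)=C(C(=O)OC)C1c1cccc(Cl)c1Cl`, is reached from compound 2 by one change: chloro in place of hydrogen on an aromatic carbon. For the measured compounds named here, no measured pair shows this exact step, so its size is not known from the series. Compound 1 carries the same 2,3-dichlorophenyl and gives 5.01 nM, which is taken as a pointer rather than a measurement of the step.

The expected step from compound 2 to compound 3 is a 5.0-fold lower number from compound 2 to compound 3 (0.70 log units; beyond the scatter), toward a lower number. Compound 3 is accordingly estimated at 20 nM in this assay, with a range from 5 nM to 80 nM.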

Compound 3, half-maximal inhibitory concentration: 15.9 nM
For compound 3 the middle estimate is 1.3-fold (0.10 log units) above the measured one; the measured number falls inside the stated range.
By their numbers in this assay, from the lowest: compound 1; then compound 3; then compound 2.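

In this assay the change from 2-chlorophenyl to 2,3-dichlorophenyl, chloro in place of hydrogen on an aromatic carbon ortho to a chloro group and meta to a large group, now has a size of its own: a 6.3-fold lower number from compound 2 to compound 3 (0.80 log units; beyond the scatter) with the carbamoyl present, which the earlier pair could not show because it differed in more than one place. Compound 3 also isolates the other difference, since adding the carbamoyl gives a 3.2-fold higher number from compound 1 to compound 3 (0.50 log units; beyond the scatter) with the 2,3-dichlorophenyl held constant, so each of the two changes accounts for part of the gap between the first two compounds. Nothing at hand gives a reason for either step.

From the compounds shown here alone, each step is known in one context only, so it remains open whether the chloro step holds without the carbamoyl and whether the carbamoyl step holds on the 2-chlorophenyl. Also open, going by these compounds, is how fluoro, methyl or methoxy would compare with chloro at this ring position, and how a carboxylic acid, a nitrile or an aminomethyl group would compare with the carbamoyl.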